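Trifluoromethyl on the anilino ring of compound 2

A few compounds are considered here, and "the series" means these few. Any claim that something is new, unique, unknown or untested is made for them only; others in the source may bear on it.

Measured compounds, all in a functional assay on PC-3 cells (Homo sapiens) for inhibition, read by MTT assay, with a stated time of 72 h; a higher number here means a weaker inhibitor, a lower number a stronger inhibitor:
compound 1 `O=C(CSc1nc(Nc2ccccc2)c2ccccc2n1)Nc1ccccc1Cl` gives 14600 nM
compound 2 `C=CC(=O)Nc1cccc(NC(=O)CSc2nc(Nc3ccccc3)c3ccccc3n2)c1` gives 8740 nM
compound 3 `O=C(CSc1nc(Nc2ccccc2)c2ccccc2n1)Nc1ccc(C(F)(F)F)cc1` gives 10400 nM

Compound 2 has the lowest number of the three, but its neighbours sit close: a 1.7-fold lower number from compound 1 to compound 2 (0.22 log units; within the scatter) and a 1.2-fold higher number from compound 2 to compound 3 (0.08 log units; within the scatter) both fall within the scatter, so no order among compounds 1, 2 and 3 can be read from this assay.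

Compound 4 `C=CC(=O)Nc1cccc(NC(=O)CSc2nc(Nc3ccc(C(F)(F)F)cc3)c3ccccc3n2)c1` is not yet measured. It differs from compound 2 in one place: trifluoromethyl in place of hydrogen on an aromatic carbon. The change reads anilino to (4-(trifluoromethyl)phenyl)amino on the shared core.

Within the data shown here, no measured step touches this ring. All three steps exchange the aryl on the amide-type nitrogen, and each is within the scatter: a 1.7-fold lower number from compound 1 to compound 2 (0.22 log units; within the scatter), a 1.4-fold lower number from compound 1 to compound 3 (0.15 log units; within the scatter), a 1.2-fold higher number from compound 2 to compound 3 (0.08 log units; within the scatter). The nearest comparison is a 1.4-fold lower number from compound 1 to compound 3 (0.15 log units; within the scatter), which introduces the same trifluoromethyl group, though on the other aryl, without a step beyond the scatter. On these data the series has so far been flat, so no step beyond the scatter is expected for compound 4 in this assay.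

Compound 4 is therefore estimated at 8000 nM, within 3500 nM to 18000 nM, meaning an expected step of a 1.1-fold lower number from compound 2 to compound 4 (0.04 log units; within the scatter).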

Compound 4, half-maximal inhibitory concentration: 12500 nM
Compound 4: middle estimate off by 1.6-fold (0.19 log units), on the low side, within the range that was stated.
By their numbers in this assay, from the lowest: compounds 2, 3, 4 and 1 (each within the scatter of the next).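

The anilino ring now has its first reading: in this assay, trifluoromethyl in place of hydrogen on an aromatic carbon, para to a large group, gives a 1.4-fold higher number from compound 2 to compound 4 (0.16 log units; within the scatter) and so does not separate the two compounds. The earlier steps shown here exchanged only the aryl on the amide-type nitrogen, so this result extends the absence of any step beyond the scatter to a second site on the shared core, though for this one group at this one place. No supporting measurement accompanies the result, and nothing can be said about what lies behind it.

Whether a hydroxyl, an amine or a carboxylic acid at this place on the anilino ring would give a step beyond the scatter stays open, since no step of that size appears among the compounds shown. Also open, going by these compounds, is whether trifluoromethyl on this ring would read the same with 2-chlorophenyl or 4-(trifluoromethyl)phenyl on the amide-type nitrogen instead of 3-((vinylcarbonyl)amino)phenyl.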